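Alkoxy chains at a shared limit, and compound 4

A few compounds are considered here, and "the series" means these few. Any claim that something is new, unique, unknown or untested is made for them only; others in the source may bear on it.

In an ADME assay on RAW264.7 cells (Mus musculus) for cytotoxicity, read by MTT assay (a higher number here means a weaker inhibitor, a lower number a stronger inhibitor), compound 1 (`CCCCCCCCOc1cccc(O)c1C(=O)/C=C/c1ccc(O)cc1`) gives > 30000 nM as a limit, not a number. Compound 2 (`CCCCCCCCCCCCOc1cccc(O)c1C(=O)/C=C/c1ccc(O)cc1`) gives > 30000 nM as a limit too. Compound 3 (`CCCCCCCCCCCCCCCCCCOc1cccc(O)c1C(=O)/C=C/c1ccc(O)cc1`) likewise gives > 30000 nM as a limit. Within the data shown here, compound 1 therefore has no readable rank among its neighbours, and the whole series so far comes down to one observation (the limit of > 30000 nM in this assay, at which 3 of the 3 values shown sit).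

Compound 4 (`O=C(/C=C/c1ccc(O)cc1)c1c(O)cccc1OCC1CCCCC1`) keeps the core of compound 1 and changes only the chain (cyclohexyl in place of heptyl on a saturated chain carbon bound to an oxygen on an aromatic ring): cyclohexyl in place of heptyl on a saturated chain carbon bound to an oxygen on an aromatic ring. The same difference reads octyloxy to cyclohexylmethoxy.

The measured steps that bear on this change all sit in the same chain: (a step that the two limits leave unreadable from compound 1 to compound 2), (a step that the two limits leave unreadable from compound 1 to compound 3) and (a step that the two limits leave unreadable from compound 2 to compound 3). None has a size that can be read, and none brings in a ring, so the evidence is thin.

The step expected is a step that the limit leaves unreadable from compound 1 to compound 4 in this assay, with none beyond the scatter anticipated in either direction. Compound 4 will most likely be reported as a limit again. The estimate for compound 4 is 40000 nM (expected range 15000 nM to 100000 nM).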

Compound 4, half-maximal inhibitory concentration: > 30000 nM
Compound 4: no number, only a limit (the forecaster's own chance of this, stated with the estimate: 80%); the middle value lies beyond the limit too.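

In this assay compound 4 gives > 30000 nM, a limit and not a number. Among these compounds, no step from compound 1 to compound 4 can be read, as both compounds carry only limits. The compounds shown leave open whether the octyloxy and cyclohexylmethoxy chains differ at all in this assay, as every value is a limit: the limit of > 30000 nM in this assay, at which 4 of the 4 values shown sit.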